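Swapping Methoxy for Methyl on the Aryl Ring

This account rests on a few compounds, and the source may have more. Where it says the series, first, only, none or still open, it means among the compounds named here.

Three measured compounds share one core and differ only in the aryl group attached to it. Compound 1 `CCCCc1ccc(-c2cc(=O)c3c(o2)C(CC)(CC)C(=O)C(CC)=C3O)cc1` gives 37 uM in a functional assay on KBVIN cells (Homo sapiens) for antiproliferative activity, read by sulforhodamine B assay, with a stated time of 3 days (on this read-out higher numbers stand for an effect only at larger amounts of compound and lower numbers for an effect already at smaller amounts), compound 2 `CCC1=C(O)c2c(oc(-c3ccc(CC(C)C)cc3)cc2=O)C(CC)(CC)C1=O` gives 17.4 uM, and compound 3 `CCC1=C(O)c2c(oc(-c3ccc(OC)cc3)cc2=O)C(CC)(CC)C1=O` gives 0.68 uM, the lowest of the three numbers. Compound 4 `CCC1=C(O)c2c(oc(-c3cccc(C)c3)cc2=O)C(CC)(CC)C1=O` is the next step: 3-methylphenyl in place of 4-methoxyphenyl on an aromatic carbon. For the measured compounds named here, the steps that bear on it are those leading into compound 3, namely a 54-fold lower number from compound 1 to compound 3 (1.74 log units; beyond the scatter) and a 26-fold lower number from compound 2 to compound 3 (1.41 log units; beyond the scatter), where a methoxy replacing an alkyl group produced large drops. Compound 4 gives the methoxy up for a methyl, so its number is expected to rise, though perhaps not by the full amount seen for the longer chains. Compound 4 is therefore estimated at 8 uM, within 2 uM to 30 uM, which means an expected step of a 12-fold higher number from compound 3 to compound 4 (1.07 log units; beyond the scatter).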

Compound 4, concentration for half-maximal effect: 3.69 uM
The estimate for compound 4 lay 2.2-fold (0.34 log units) above the measured number; low and high end bracket the measured number.
By their numbers in this assay, from the lowest: compound 3; then compound 4; then compound 2; then compound 1.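

In this assay the aryl group can lose its oxygen and keep much of its effect: a 5.4-fold higher number from compound 3 to compound 4 (0.73 log units; beyond the scatter) is only a modest rise, and a far smaller one than the large steps that lead from the butyl and isobutyl compounds to compound 3. This single step both replaces the group and moves it on the ring, so the two changes cannot be told apart here. No measurement shown explains the rise. The compounds shown leave open whether the group or its place on the ring matters more. They also leave open how an amine or a carboxylic acid on this aryl ring would read.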